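Trifluoromethyl in place of isopropyl on the shared core

The compounds below may be only part of what the source reports. "The series", "measured", "known", "first", "only" and "open" are said of these compounds alone.

Measured so far in an ADME assay on microsomes from liver (Homo sapiens) for metabolic stability; on this read-out lower numbers stand for a shorter-lived compound and higher numbers for a longer-lived compound:
compound 1 `CCc1cccc2ccc(-c3ccc(C(/C=C4\OC(=O)NC4=O)(CC)CC)c(=O)[nH]3)cc12` gives 0.178 h
compound 2 `CCC(/C=C1\OC(=O)NC1=O)(CC)c1ccc(-c2ccc3cccc(C(C)C)c3c2)[nH]c1=O` gives 0.758 h

Compound 2 holds the higher of the two numbers, and the gap to compound 1 lies beyond the scatter. Compound 3 `CCC(/C=C1\OC(=O)NC1=O)(CC)c1ccc(-c2ccc3cccc(C(F)(F)F)c3c2)[nH]c1=O` carries trifluoromethyl in place of isopropyl on an aromatic carbon on the same core. For the measured compounds named here, only one measured step bears on this change: a 4.3-fold higher number from compound 1 to compound 2 (0.63 log units; beyond the scatter), a modest rise beyond the scatter at the same substituent. Going by the values given here, no measured compound carries trifluoromethyl, so the expectation is tentative. The expected change is a 2.0-fold higher number from compound 2 to compound 3 (0.30 log units; within the scatter), a modest rise in this assay at most. Compound 3 is estimated at 1.5 h, with an expected range from 0.6 h to 4 h on this read-out.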

Compound 3, half-life: 0.353 h
Compound 3: the middle estimate sits 4.2-fold (0.63 log units) above what was measured; the whole stated range lies above it.
By their numbers in this assay, from the lowest: compounds 1 and 3 (each within the scatter of the next); then compound 2.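

In this assay trifluoromethyl on this aromatic carbon gives a 2.1-fold lower number from compound 2 to compound 3 (0.33 log units; beyond the scatter) here, so of the three groups shown at this position isopropyl holds the highest number. In place of ethyl, the same group gives a 2.0-fold higher number from compound 1 to compound 3 (0.30 log units; within the scatter) here, so these two groups are not separated on this read-out. Nothing on hand explains why isopropyl stands apart from both. Still open, as far as these compounds go, is how a tert-butyl or a methoxy group on this aromatic carbon would stand against isopropyl. Also open, from the compounds shown here alone, is whether isopropyl keeps its place on any core other than the shared one.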